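Removing One Methyl From the Shared Core

This account rests on a few compounds, and the source may have more. Where it says the series, first, only, none or still open, it means among the compounds named here.

Compound 2, `Cc1c(C)c2ccc(OCC3CCN(Cc4cccc(CO)c4)CC3)cc2oc1=O`, was tested in an assay for inhibition of Amine oxidase [flavin-containing] A (Homo sapiens), read by fluorescence, using microsomes, with a stated time of 30 min (a higher number here means a weaker inhibitor, a lower number a stronger inhibitor), where compound 2 gives 1900 nM. For the measured compounds named here, the only other compound measured, compound 1, `Cc1c(C)c2ccc(OCC3CCCN(Cc4ccc(CO)cc4)C3)cc2oc1=O`, gives 1100 nM in this assay; compound 2 sits at the top of these two numbers, yet the gap between them lies within the scatter, so the two cannot be told apart. Compound 3, `Cc1cc(=O)oc2cc(OCC3CCN(Cc4cccc(CO)c4)CC3)ccc12`, is still unmeasured. It differs from compound 2 in one place: hydrogen in place of methyl on an aromatic carbon. Going by the values given here, no measured pair shows this change, so only a small step toward a weaker inhibitor is expected, possibly not beyond the scatter. Compound 3 is estimated at 2600 nM, within a range of 1000 nM to 6500 nM, an expected step of a 1.4-fold higher number from compound 2 to compound 3 (0.14 log units; within the scatter).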

Compound 3, half-maximal inhibitory concentration: 3500 nM
Compound 3: the middle estimate sits 1.3-fold (0.13 log units) below what was measured, and the stated range covers the measured number.
By their numbers in this assay, from the lowest: compounds 1, 2 and 3 (each within the scatter of the next, the first and the last beyond it).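

For the compounds shown here, this pair is the first measured one that differs in only one place, giving a direct reading of hydrogen in place of methyl on an aromatic carbon, two atoms from the ring oxygen. In this assay the change gives a 1.8-fold higher number from compound 2 to compound 3 (0.27 log units; within the scatter), so the two compounds cannot be told apart and this methyl shows no clear effect. No supporting data bear on this result. Still open, on these data alone, is whether the remaining methyl on the shared core matters, and whether an ethyl group or a chlorine atom at this position would move the number beyond the scatter.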